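The source may hold more compounds than are shown below. What is called first, only, known or untested is meant among the compounds shown, and "the series" means these compounds.

Compound 1, `Nc1nc(N)c(CCCNc2cc(F)ccc2[N+](=O)[O-])c(O)n1`, is the simplest member of this set. In a functional assay on CCRF-CEM cells (Homo sapiens) for cytotoxicity, in the absence of a further agent (a lower number here means a stronger inhibitor, a higher number a weaker inhibitor), compound 1 gives > 100000 nM, which is a limit of the assay and not a number. Compound 2, `Nc1nc(N)c(CCCNc2cc(F)cc(F)c2[N+](=O)[O-])c(O)n1`, gives 97000 nM in this assay. Compound 2 and compound 1 differ by hydrogen in place of fluoro on an aromatic carbon, and the step made is an at least 1.0-fold higher number from compound 2 to compound 1 (0.01 log units; that floor lies within the scatter). Compound 3, `Nc1nc(N)c(CCCN(Cc2ccc(NC(CCC(=O)O)C(=O)O)cc2)c2cc(F)cc(F)c2[N+](=O)[O-])c(O)n1`, is a larger molecule built on the same core as compound 2; the difference between the two cores is not broken down here. In this assay compound 3 gives > 100000 nM, again a limit of the assay rather than a number. Compound 4, `Nc1nc(N)c(CCCN(Cc2ccc(NC(CCC(=O)O)C(=O)O)cc2)c2cc(F)ccc2[N+](=O)[O-])c(O)n1`, has not yet been measured in this assay. It differs from compound 3 by hydrogen in place of fluoro on an aromatic carbon, the same change at the same place as that leading from compound 2 to compound 1, and that change left no step beyond the scatter between compound 2 and compound 1. The reading is constrained because of the limit of > 100000 nM in this assay, at which 2 of the 3 values shown sit, so there is little room for the change to show a measurable effect. Compound 4 is therefore expected to give 150000 nM, with the range estimated from 80000 nM to 300000 nM. This expectation amounts to an estimated step that the limit leaves unreadable from compound 3 to compound 4, resting on compound 3 whose reading is > 100000 nM, a limit, and on the step of an at least 1.0-fold higher number from compound 2 to compound 1 (0.01 log units; that floor lies within the scatter), which stayed within the scatter.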

Compound 4, half-maximal inhibitory concentration: > 100000 nM
Compound 4 gave a limit, no number; the forecaster's own chance of this, stated with the estimate: 85%; the middle value is on the limit's open side.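

For the compounds shown here, compound 3 and compound 4 both stop at a limit of the assay rather than a number, so no step between them can be read in this assay: the limit of > 100000 nM in this assay, at which 3 of the 4 values shown sit.

The compounds shown leave open whether going from 3,5-difluoro-2-nitrophenyl to 5-fluoro-2-nitrophenyl changes anything in the larger molecules, and what actual values compound 3 and compound 4 would have.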